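Swapping a Small Ring for a Larger One on the Nitrogen

The source may hold more compounds than are shown below. What is called first, only, known or untested is meant among the compounds shown, and "the series" means these compounds.

Compound 3 `CC(C)c1onc(-c2c(Cl)cccc2Cl)c1COc1ccc(-c2nc3ccc(C(=O)O)cc3n2C2CC2)cc1` has the highest number of the three measured compounds in an assay on Huh-7 cells for agonist activity at Bile acid receptor (Homo sapiens), read by a luciferase reporter (on this read-out higher numbers stand for an effect only at larger amounts of compound and lower numbers for an effect already at smaller amounts), giving 16.5 nM. Compound 2 `CC(C)c1onc(-c2c(Cl)cccc2Cl)c1COc1ccc(-c2nc3ccc(C(=O)O)cc3n2CC(C)(C)C)cc1` gives 13 nM, and the step of a 1.3-fold higher number from compound 2 to compound 3 (0.10 log units; within the scatter) lies within the scatter, so these two cannot be ordered. Compound 1 `CCC(CC)n1c(-c2ccc(OCc3c(-c4c(Cl)cccc4Cl)noc3C(C)C)cc2)nc2ccc(C(=O)O)cc21` gives 0.8 nM, and the steps of a 16-fold higher number from compound 1 to compound 2 (1.21 log units; beyond the scatter) and a 21-fold higher number from compound 1 to compound 3 (1.31 log units; beyond the scatter) show how strongly the group on the aromatic nitrogen matters. Compound 4 `CC(C)c1onc(-c2c(Cl)cccc2Cl)c1COc1ccc(-c2nc3ccc(C(=O)O)cc3n2C2CCCCCC2)cc1` differs from compound 3 by cycloheptyl in place of cyclopropyl on an aromatic nitrogen. Cycloheptyl is much larger than cyclopropyl and nearer in size to the pentan-3-yl of compound 1, whose 0.8 nM is the lowest shown, so a move in that direction is expected, though cautiously, since no measured ring of this size exists. The expected step is a 3.3-fold lower number from compound 3 to compound 4 (0.52 log units; beyond the scatter). Compound 4 is therefore estimated at 5 nM, between 1 nM and 25 nM.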

Compound 4, half-maximal effective concentration: 14.8 nM
Beside the measured number, compound 4's estimate is 3.0-fold (0.47 log units) below it, within the range that was stated.
By their numbers in this assay, from the lowest: compound 1; then compounds 2, 4 and 3 (each within the scatter of the next).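

In this assay, the cycloheptyl ring and the cyclopropyl ring cannot be told apart (a 1.1-fold lower number from compound 3 to compound 4 (0.05 log units; within the scatter)), so this change in ring size on the aromatic nitrogen shows no measurable effect. Cycloheptyl and neopentyl cannot be told apart either (a 1.1-fold higher number from compound 2 to compound 4 (0.06 log units; within the scatter)), yet pentan-3-yl keeps a large lead over the larger ring (a 19-fold higher number from compound 1 to compound 4 (1.27 log units; beyond the scatter)), so a larger group alone does not match it. No measured evidence explains this gap.

Still open, going by these compounds, is how a longer branched chain such as heptan-4-yl would compare with pentan-3-yl. Also open, on these data alone, is where a cyclopentyl ring would fall.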